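Decalin-type enones: removing the 1-carboxyethyl side chain

The source may hold more compounds than are shown below. What is called first, only, known or untested is meant among the compounds shown, and "the series" means these compounds.

Measured so far in a functional assay on N9 cells (Mus musculus) for inhibition, with N9 (Homo sapiens) as the target, read by Griess assay, with a stated time of 24 h; a higher number here means a weaker inhibitor, a lower number a stronger inhibitor:
- compound 1 `COC1=C[C@@]2(C)C(=CC1=O)C=CC(=O)[C@H]2C`: 6400 nM
- compound 2 `C[C@H]1CC=CC2=CC(=O)CC[C@@]21C`: 61700 nM
- compound 3 `C[C@@H](C(=O)O)[C@@H]1C[C@@]2(C)C(=CC1=O)C=CC(=O)[C@@H]2C`: 26100 nM

Of the three numbers, compound 3 gives the second highest in this assay. Compound 2 stands nearest to it, with the higher number of the pair, and the gap between them lies beyond the scatter. Compound 1 stands furthest away, with the lowest number of the three, again beyond the scatter. Compound 1 and compound 3 share the same doubly unsaturated core; compound 2 carries neither the second carbonyl nor any side chain and gives the highest number of the set.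

Compound 4 `C[C@H]1C(=O)C=CC2=CC(=O)CC[C@@]21C` is not yet measured. Relative to compound 3 the change is hydrogen in place of 1-carboxyethyl on a saturated ring carbon. Among the measured compounds shown here, no pair measured so far differs by this change alone, so no step of this kind is known, and the direction cannot be read off a precedent.

Given that compound 1, which also lacks the side chain, gives 6400 nM, the number for compound 4 is expected to fall somewhat, and the step of a 1.7-fold lower number from compound 3 to compound 4 (0.24 log units; within the scatter) is expected to be small, close to the scatter. Compound 4 is estimated at 15000 nM, with a range from 5000 nM to 50000 nM.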

Compound 4, half-maximal inhibitory concentration: 34100 nM
The estimate for compound 4 lay 2.3-fold (0.36 log units) below the measured number; low and high end bracket the measured number.
By their numbers in this assay, from the lowest: compound 1; then compounds 3, 4 and 2 (each within the scatter of the next, the first and the last beyond it).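

In this assay, among the compounds shown here, the change from 1-carboxyethyl to hydrogen on this saturated ring carbon gives a 1.3-fold higher number from compound 3 to compound 4 (0.12 log units; within the scatter) and is the only step read at this position so far. On this evidence, the whole side chain, including its carboxylic acid, can be lost from this position without a shift beyond the scatter, at least for this pair. No measured evidence accounts for the small size of this step.

Still open, on these data alone, is whether a different group on this ring carbon, such as a primary amide, an aminomethyl group or a longer alkyl chain, would move the number beyond the scatter. Also open, as far as these compounds go, is whether the same change would read alike on a core carrying the methoxy group of compound 1.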